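Sulfanyl-linked series: cytotoxicity and the step to compound 4

The source may hold more compounds than are shown below. What is called first, only, known or untested is meant among the compounds shown, and "the series" means these compounds.

Compound 1 `C#CCSc1nnc(C)n1N1C(=O)c2ccccc2C1=O` in a functional assay on PC-3M cells (Homo sapiens) for cytotoxicity, read by MTT assay, with a stated time of 48 h (a lower number here means a stronger inhibitor, a higher number a weaker inhibitor), gives > 200000 nM, a limit of the assay and not a number.
Compound 2 `CCc1nnc(SCc2ccccc2)n1N1C(=O)c2ccccc2C1=O` in this assay gives > 200000 nM, likewise a limit.
Compound 3 `C#CCSc1nnc(-c2cc(OC)c(OC)c(OC)c2)n1N1C(=O)c2ccccc2C1=O` in this assay gives > 200000 nM, again a limit.

Among the compounds with values here, compound 3 therefore stands at the limit of > 200000 nM in this assay, at which 3 of the 3 values shown sit; none of the three measured compounds yields a number, so no measured step exists and no ordering can be read among them.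

Compound 4 `COc1cc(-c2nnc(SCC(=O)c3ccc(F)c(F)c3)n2N2C(=O)c3ccccc3C2=O)cc(OC)c1OC` differs from compound 3 by (3,4-difluorophenyl)carbonyl in place of ethynyl on a saturated chain carbon bound to a sulfur. Within the data shown here, no measured step in this assay bears on this change, so the expected step is uncertain; the step from compound 3 to compound 4 is estimated as an at least 1.3-fold lower number from compound 3 to compound 4 (0.12 log units; that floor lies within the scatter), most likely no movement beyond the scatter from the limit. Compound 4 is expected to give 150000 nM in this assay, within 30000 nM to 400000 nM.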

Compound 4, half-maximal inhibitory concentration: 163000 nM
Beside the measured number, compound 4's estimate is 1.1-fold (0.04 log units) below it, within the range that was stated.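

In this assay, within the data shown here, compound 4 gives 163000 nM as the first value of the series that is a number and not a limit. Placing (3,4-difluorophenyl)carbonyl in place of ethynyl on a saturated chain carbon bound to a sulfur yields an at least 1.2-fold lower number from compound 3 to compound 4 (0.08 log units; that floor lies within the scatter) and so fixes only a floor for this change. The other compounds remain at a limit: the limit of > 200000 nM in this assay, at which 3 of the 4 values shown sit.

From the compounds shown here alone, whether the carbonyl or the difluorophenyl ring matters for this step stays open. So does the reading at this position with an amine, a carboxylic acid or a longer chain.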